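Tert-Butyl for 4-Fluorophenyl: Expected Effect on Cytotoxicity

This account rests on a few compounds, and the source may have more. Where it says the series, first, only, none or still open, it means among the compounds named here.

Compound 1 `O=C(O)c1cn(-c2ccc(F)cc2)c2nc(N3CCN(C(c4ccccc4)c4ccc(Cl)cc4)CC3)c([N+](=O)[O-])cc2c1=O`: 102000 nM
Compound 2 `CC(C)(C)NC(=O)C1c2ccccc2CCN1c1nc2c(cc1[N+](=O)[O-])c(=O)c(C(=O)O)cn2-c1ccc(F)cc1`: 112000 nM
Compound 3 `CC(C)(C)n1cc(C(=O)O)c(=O)c2cc([N+](=O)[O-])c(N3CCN(C(c4ccccc4)c4ccc(Cl)cc4)CC3)nc21`: > 108000 nM

These three compounds were measured in an ADME assay on Vero cells (Chlorocebus sabaeus) for cytotoxicity, read by MTT assay, with a stated time of 72 h; on this read-out higher numbers stand for weaker inhibition and lower numbers for stronger inhibition. The number given for compound 3 is a limit of the assay rather than a measured value: the limit of > 108000 nM in this assay, at which 1 of the 3 values shown sits. Compound 1 and compound 3 share a core and differ in a single place, (tert-butyl in place of 4-fluorophenyl on an aromatic nitrogen), and this change gave an at least 1.0-fold higher number from compound 1 to compound 3 (0.02 log units; that floor lies within the scatter). Compound 2 has a different core; how it differs from compound 1 is not broken down here. In this assay compound 2 gives 112000 nM, which lies within the usual scatter of the value of compound 1, so no order between the two can be read.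

Compound 4 `CC(C)(C)NC(=O)C1c2ccccc2CCN1c1nc2c(cc1[N+](=O)[O-])c(=O)c(C(=O)O)cn2C(C)(C)C` has not yet been measured. It carries the same change on the core of compound 2 that was made from compound 1 to compound 3, (tert-butyl in place of 4-fluorophenyl on an aromatic nitrogen). Since an at least 1.0-fold higher number from compound 1 to compound 3 (0.02 log units; that floor lies within the scatter) stayed within the scatter, a step of similar size is expected here. The expected step is a 1.1-fold higher number from compound 2 to compound 4 (0.03 log units; within the scatter). Compound 4 is therefore estimated at 120000 nM, with a range from 60000 nM to 250000 nM, and a fair chance that only a limit is reported.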

Compound 4, half-maximal inhibitory concentration: 120000 nM
Compound 4: middle estimate and measured number agree at the digits printed, within the range that was stated.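

In this assay, tert-butyl in place of 4-fluorophenyl on an aromatic nitrogen gave a 1.1-fold higher number from compound 2 to compound 4 (0.03 log units; within the scatter). Set beside the earlier case, the same change on the two cores reads as follows: the same change on two cores in this assay, an at least 1.0-fold higher number (0.02 log units; that floor lies within the scatter) from compound 1 to compound 3 and a 1.1-fold higher number (0.03 log units; within the scatter) from compound 2 to compound 4; the limit leaves it open whether they differ. For the compounds shown here, compound 3 gives > 108000 nM, which is a limit of the assay and not a number, so the data show only that the step on the core of compound 2 stayed within the scatter and do not show that the change carries over unaltered from one core to another.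

On these data alone, whether a smaller or a ring-bearing group on that aromatic nitrogen, such as ethyl or cyclopropyl, would also leave the number within the scatter remains open. As far as these compounds go, two cores also make a narrow basis, so it remains open whether the same holds on a core with another group in place of the carboxylic acid, such as a primary amide.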